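This account rests on a few compounds, and the source may have more. Where it says the series, first, only, none or still open, it means among the compounds named here.

Compound 1, `CCCCN(CC)c1cc(C)nc2c1NC(=O)CN2c1ccc(C(C)C)cc1Br`: 0.7%.
Compound 2, `CCCCN(CC)c1cc(C)nc2c1NC(=O)CN2c1ccc(Cl)cc1Cl`: 0.9%.
Compound 3, `CCCCN(CC)c1cc(C)nc2c1NC(=O)CN2c1ccc(I)cc1C`: "not determined" (no result reported).

These three compounds share one core and differ only in the groups on the aromatic ring attached to it. They were examined in an assay on HEK-293T cells for displacement of a labelled ligand from corticotropin-releasing factor receptor 2 (Homo sapiens), read by scintillation counting, with a stated time of 2 h, tested at 1 uM; a higher number here means more inhibition at the concentration tested (going by the name of the read-out), a lower number less inhibition. In this assay compound 1 gives 0.7% and compound 2 gives 0.9%; both numbers sit close to zero, and the gap between them lies within the usual scatter, so the two cannot be told apart. For compound 3 the entry reads "not determined" (no result reported), so it adds nothing to the comparison.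

The unmeasured compound 4, `CCCCN(CC)c1cc(C)nc2c1NC(=O)CN2c1ccc(C)cc1Br`, is reached from compound 1 by one change: methyl in place of isopropyl on an aromatic carbon. For the measured compounds named here, with both measured numbers near zero, there is no step between measured compounds to lean on, and a shorter chain in this place is expected to leave the read-out essentially where it was, with no step beyond the scatter. Compound 4 is therefore expected to give about 2% in this assay, most likely between -6% and 12%. That estimate means a step of a number 1.3 percentage points higher from compound 1 to compound 4 (within the scatter), expected to be small.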

Compound 4, a percentage reported as inhibition, at one concentration (the size of the read-out at that concentration, not a potency): 5.5%
Compound 4: middle estimate off by 3.5 percentage points, on the low side, and the stated range covers the measured number.
By their numbers in this assay, from the lowest: compounds 1, 2 and 4 (each within the scatter of the next).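

Putting methyl in place of isopropyl on this aromatic carbon, meta to a bromo group and para to a large group, gives in this assay a number 4.8 percentage points higher from compound 1 to compound 4 (within the scatter) and so does not move the read-out beyond the scatter. For the compounds shown here, this is the first direct test of this position, and the smaller group leaves inhibition at the tested concentration indistinguishable from that of the isopropyl compound. The wider swap of 2,4-dichlorophenyl for 2-bromo-4-methylphenyl gives a number 4.6 percentage points higher from compound 2 to compound 4 (within the scatter) and likewise stays inside the scatter, while nothing available explains these small numbers.

Going by these compounds, compounds 1, 2 and 4 all give low numbers, so whether any group on this carbon can produce clear inhibition remains open. An amine, a carboxylic acid or a longer chain such as hexyl there could still behave differently.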